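The source may hold more compounds than are shown below. What is called first, only, known or untested is meant among the compounds shown, and "the series" means these compounds.

Values in an ADME assay on BCBL1 cells (Homo sapiens) for cytotoxicity, with a stated time of 7 days; on this read-out higher numbers stand for lower toxicity in this test and lower numbers for higher toxicity in this test:
- Compound 1 `Nc1nc(OCC(F)(F)F)c2ncn(/C=C3/CC3(CO)CO)c2n1`: > 20000 nM, a limit.
- Compound 2 `Nc1nc(OCc2ccccc2)c2ncn(/C=C3/CC3(CO)CO)c2n1`: > 20000 nM, a limit.
- Compound 3 `CC(C)Sc1nc(N)nc2c1ncn2/C=C1/CC1(CO)CO`: > 20000 nM, a limit.

Within the data shown here, the series so far shows (the limit of > 20000 nM in this assay, at which 3 of the 3 values shown sit). Compound 3 therefore has no numerical value, and it stands level with the other two compounds only as far as their limits show.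

The next structure is compound 4 `CCCOc1nc(N)nc2c1ncn2/C=C1/CC1(CO)CO`, with propoxy in place of isopropylsulfanyl on an aromatic carbon.

The steps bearing most directly on this change are a step that the two limits leave unreadable from compound 1 to compound 3 and a step that the two limits leave unreadable from compound 2 to compound 3, both on the same aromatic carbon. The remaining one is a step that the two limits leave unreadable from compound 1 to compound 2. None of the three has a readable size, so no direction can be drawn from them. No step beyond the scatter is expected in this assay, and a further limit is the likeliest report. The expected change is a step that the limit leaves unreadable from compound 3 to compound 4. For compound 4 the estimate is 30000 nM, with an expected range from 12000 nM to 100000 nM.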

Compound 4, half-maximal cytotoxic concentration: > 20000 nM
Compound 4 ended at the assay's limit; the forecaster's own chance of this, stated with the estimate: 85%; the middle value lies beyond the limit too.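

Among these compounds, compound 4 is also a limit in this assay, so no step from compound 1, compound 2 or compound 3 to compound 4 can be read: the limit of > 20000 nM in this assay, at which 4 of the 4 values shown sit. The compounds shown leave open whether any group on this aromatic carbon brings a numerical value within the range of the test.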